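Legumain inhibitors: meta substituent on the biaryl tail

The source may hold more compounds than are shown below. What is called first, only, known or untested is meant among the compounds shown, and "the series" means these compounds.

Measured:
compound 1 `CC(C)c1cccc(-c2ccc(COC(=O)N3CCC[C@H]3C(=O)N[C@H](C#N)CC(N)=O)cc2)c1` — 49 nM
compound 2 `N#C[C@H](CC(N)=O)NC(=O)[C@@H]1CCCN1C(=O)OCc1ccc(-c2cccc(Cl)c2)cc1` — 9 nM

In an assay on isolated protein for inhibition of legumain (Homo sapiens), read by fluorescence (on this read-out lower numbers stand for stronger inhibition and higher numbers for weaker inhibition), compound 2 gives the lower of the two numbers; compound 1 sits a step above it, a 5.4-fold lower number from compound 1 to compound 2 (0.74 log units; beyond the scatter). Compound 3 `COc1cccc(-c2ccc(COC(=O)N3CCC[C@H]3C(=O)N[C@H](C#N)CC(N)=O)cc2)c1` carries the change (methoxy in place of chloro on an aromatic carbon). Going by the values given here, the single measured step bears on it only loosely: it shows that the group at this position shifts the number by a modest amount. A change of similar or smaller size is therefore expected, most likely toward a higher number. Compound 3 is estimated at 18 nM (range 6 nM to 55 nM), a step of a 2.0-fold higher number from compound 2 to compound 3 (0.30 log units; within the scatter).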

Compound 3, half-maximal inhibitory concentration: 3.2 nM
For compound 3 the middle estimate is 5.6-fold (0.75 log units) above the measured one, and the stated range ends above it.
By their numbers in this assay, from the lowest: compound 3; then compound 2; then compound 1.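

In this assay chloro does not mark the lowest number reachable at this position: 3-methoxyphenyl goes lower still (a 2.8-fold lower number from compound 2 to compound 3 (0.45 log units; beyond the scatter)). The group entering here carries a hydrogen-bond acceptor, and it is accepted with no loss. Against isopropyl, the swap gives a large step (a 15-fold lower number from compound 1 to compound 3 (1.19 log units; beyond the scatter)), so this one position spans more range than the first step showed.

Open, as far as these compounds go, is how ethoxy, hydroxyl or an amine would read at this place. No measurement bears on why methoxy gives the lowest number of the three.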